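The compounds below may be only part of what the source reports. "The series", "measured", "known", "first", "only" and "open" are said of these compounds alone.

Among the measured compounds shown here, in an ADME assay on CRFK cells (Felis catus) for cytotoxicity (a higher number here means that more compound is tolerated, a lower number that less compound is tolerated), only two readings exist so far. Compound 1 (`CCN(CC)CN1C(=O)/C(=N/NC(N)=S)c2cc(Cl)ccc21`) gives > 100000 nM as a limit of the assay, not a number. For the measured compounds named here, compound 2 (`CCN(CC)CN1C(=O)/C(=N/NC(=S)Nc2ccccc2)c2ccccc21`) gives 32300 nM as the only actual number, and so it is the sole numerical anchor available. Compound 3 (`CCN(CC)CN1C(=O)/C(=N/NC(N)=S)c2ccccc21`) differs from compound 2 by one change, hydrogen in place of phenyl on an amide-type nitrogen in all, which is hydrogen in place of phenyl on an amide-type nitrogen, or anilino to amino. Going by the values given here, no step between measured compounds sizes this change, so any expectation is tentative. Among the compounds with values here, since compound 2 at 32300 nM is the only reading that is an actual number, a moderate move toward more compound tolerated is expected, with the estimated step of a 2.6-fold higher number from compound 2 to compound 3 (0.42 log units; beyond the scatter) as its size. For compound 3 the estimated value is 85000 nM within an expected range from 40000 nM to 180000 nM in this assay.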

Compound 3, half-maximal cytotoxic concentration: 73800 nM
Compound 3: middle estimate off by 1.2-fold (0.06 log units), on the high side; the measured number falls inside the stated range.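

In this assay, hydrogen in place of phenyl on an amide-type nitrogen now has a measured size, a 2.3-fold higher number from compound 2 to compound 3 (0.36 log units; beyond the scatter), so anilino to amino at this place goes with more compound tolerated in this pair. Compound 1 gives > 100000 nM, which is a limit of the assay and not a number. Hydrogen in place of chloro on an aromatic carbon can therefore be read only as a floor, an at least 1.3-fold lower number from compound 1 to compound 3 (0.13 log units; that floor lies within the scatter), and its true size stays unknown because compound 1 stands at a limit: the limit of > 100000 nM in this assay, at which 1 of the 3 values shown sits.

Still open, as far as these compounds go, is how a methyl or a benzyl on that nitrogen would stand against phenyl and hydrogen in this assay. Also open, from the compounds shown here alone, is where a bromo or a methoxy in place of chloro on that aromatic carbon would fall.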